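Chloro for hydrogen on the pyridine ring of compound 3

A few compounds are considered here, and "the series" means these few. Any claim that something is new, unique, unknown or untested is made for them only; others in the source may bear on it.

Of the compounds shown here, three sharing one bicyclic amine core have been measured in an in vitro assay on SH-EP1 cells for displacement of a labelled ligand from Neuronal acetylcholine receptor; alpha4/beta2 (Homo sapiens); a higher number here means a weaker inhibitor, a lower number a stronger inhibitor. Compound 1 `CN1CC2C=C(c3ccc(Cl)nc3)CC(C2)C1`, which carries a methyl on the amine nitrogen and a chloro on the pyridine ring, gives 22 nM. Compound 2 `Fc1ccc(C2=CC3CNCC(C2)C3)cn1`, with a free amine and a fluoro on the ring, gives 0.4 nM. Compound 3 `C1=C(c2cccnc2)CC2CNCC1C2`, with a free amine and no substituent on the ring, gives 0.2 nM. Compound 3 stands at the lowest of the three numbers, with compound 2 nearest and compound 1 furthest away. Among the measured compounds shown here, the only single-change step among them, a 2.0-fold lower number from compound 2 to compound 3 (0.30 log units; within the scatter), shows that swapping hydrogen for fluoro at this position leaves the binding essentially unchanged.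

Compound 4 `Clc1ccc(C2=CC3CNCC(C2)C3)cn1` is the next compound, differing from compound 3 in one place: chloro in place of hydrogen on an aromatic carbon. Compound 1 and compound 4 share the chloro, but compound 1 also carries the methyl on the amine, so its value cannot be read as a guide on its own. Since the fluoro step was within the scatter, a chloro at the same place is expected to give at most a modest rise in number: for compound 4 the estimate is 0.5 nM, within 0.15 nM to 2 nM. This estimate means an expected 2.5-fold higher number from compound 3 to compound 4 (0.40 log units; beyond the scatter).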

Compound 4, inhibition constant: 0.4 nM
For compound 4 the middle estimate is 1.3-fold (0.10 log units) above the measured one; the range from low to high includes it.
By their numbers in this assay, from the lowest: compounds 3, 2 and 4 (each within the scatter of the next); then compound 1.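

Chloro in place of hydrogen on this aromatic carbon, next to the ring nitrogen, gives a 2.0-fold higher number from compound 3 to compound 4 (0.30 log units; within the scatter) in this assay and chloro in place of fluoro gives no change at the digits printed from compound 2 to compound 4 (within the scatter) in the same measurement. Together with the earlier fluoro step, this places hydrogen, fluoro and chloro at this position within the scatter of one another, so swapping among these three does not visibly shift binding to the receptor. Among the compounds shown here, compound 4 also isolates the amine nitrogen as a separate place of change, since hydrogen in place of methyl there gives a 55-fold lower number from compound 1 to compound 4 (1.74 log units; beyond the scatter) and is the only step in this set that lies beyond the scatter. No measurement is available that bears on why the number holds at one position and moves at the other.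

As far as these compounds go, whether the number would hold with something larger on the aromatic carbon, such as a methoxy group, a nitrile or an amine, remains open, as only hydrogen and two single halogen atoms appear there. It is also open whether the methyl on the amine nitrogen would have a similar effect alongside hydrogen or fluoro on the ring, as the one methyl compound shown carries chloro.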